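The compounds below may be only part of what the source reports. "The series", "measured", "known", "first", "only" and "open" are said of these compounds alone.

The three measured compounds and their values:

Compound 1, `ClCc1cccc(Cn2cnc3ncnc(Cl)c32)c1`: 3090 nM
Compound 2, `ClCc1cccc(Cn2cnc3c(Cl)ncnc32)c1`: 1660 nM
Compound 3, `ClCc1cccc(Cn2cnc3c(Cl)nc(Cl)nc32)c1`: 1770 nM

All three were tested in a functional assay on M14 cells (Homo sapiens) for cytotoxicity, read by sulforhodamine B assay, with a stated time of 48 h; on this read-out lower numbers stand for stronger inhibition of growth and higher numbers for weaker inhibition of growth. Compound 1 gives 3090 nM. Compound 2 gives 1660 nM, and compound 3 gives 1770 nM. The three numbers sit within the usual scatter of one another, so none of them can be set apart from the rest.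

Compound 1 and compound 2 share the same atoms joined differently; the difference between the two cores is not broken down here. Compound 3 differs from compound 2 by chloro in place of hydrogen on an aromatic carbon. That change made a 1.1-fold higher number from compound 2 to compound 3 (0.03 log units; within the scatter).

Compound 4, `ClCc1cccc(Cn2cnc3nc(Cl)nc(Cl)c32)c1`, has not been measured in this assay. Going by the values given here, it differs from compound 1 by chloro in place of hydrogen on an aromatic carbon, which is the same change as the one from compound 2 to compound 3, at a place described in the same words. Compound 4 is therefore expected to lie close to compound 1, with an expected step of a 1.1-fold higher number from compound 1 to compound 4 (0.03 log units; within the scatter), resting on the step of a 1.1-fold higher number from compound 2 to compound 3 (0.03 log units; within the scatter). The estimate for compound 4 in this assay is 3300 nM, with a range from 1500 nM to 7000 nM.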

Compound 4, concentration for 50% growth inhibition: 1380 nM
Estimate against measurement, compound 4: 2.4-fold (0.38 log units) above; the whole stated range lies above it.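

In this assay, chloro in place of hydrogen on an aromatic carbon gave a 2.2-fold lower number from compound 1 to compound 4 (0.35 log units; beyond the scatter), a modest step beyond the scatter, while the same change on the other core gave a 1.1-fold higher number from compound 2 to compound 3 (0.03 log units; within the scatter). Although one step lies within the scatter and the other beyond it, the gap between them is too small for the two to be told apart: the same change on two cores in this assay, a 1.1-fold higher number (0.03 log units; within the scatter) from compound 2 to compound 3 and a 2.2-fold lower number (0.35 log units; beyond the scatter) from compound 1 to compound 4, 2.4-fold (0.38 log units) apart, within the scatter of two such steps. The pair therefore gives no firm sign that the core alters the effect of this change, but neither does it show that the step carries over unchanged, since it rests on one change on two cores in a single assay.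

The compounds shown leave open whether an amine or a methoxy group in place of that chloro, between two ring nitrogen atoms, would give similar steps on both cores. They also leave open whether a step of either size would recur with a longer chain in that place.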